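Where Compound 2 Stands Before Compound 3 Is Measured

A few compounds are considered here, and "the series" means these few. Any claim that something is new, unique, unknown or untested is made for them only; others in the source may bear on it.

Measured so far in a functional assay on BGC-823 cells (Homo sapiens) for cytotoxicity, read by MTT assay; on this read-out lower numbers stand for stronger inhibition and higher numbers for weaker inhibition:
- compound 1, `Cc1nc(Nc2ccccc2)sc1C(=O)/C=C/c1ccc(Cl)cc1`: compound 1 gives only a limit, > 25000 nM
- compound 2, `Cc1nc(Nc2ccc(Cl)cc2)sc1C(=O)/C=C/c1ccc(Cl)cc1`: compound 2 gives only a limit, > 25000 nM

Compound 1 and compound 2 differ by chloro in place of hydrogen on an aromatic carbon, and the step from compound 1 to compound 2 is a step that the two limits leave unreadable from compound 1 to compound 2. Among the measured compounds shown here, compound 2 therefore stands at the limit of this assay, where no number is known for it, and the same holds for its single neighbour: the limit of > 25000 nM in this assay, at which 2 of the 2 values shown sit.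

Compound 3, `Cc1cccc(Nc2nc(C)c(C(=O)/C=C/c3ccc(Cl)cc3)s2)c1`, has not yet been measured. It differs from compound 2 by 3-methylphenyl in place of 4-chlorophenyl on a nitrogen on an aromatic ring. For the measured compounds named here, the only measured step that bears on it, a step that the two limits leave unreadable from compound 1 to compound 2, also changes the ring on that nitrogen, but its size cannot be read, so it gives neither a direction nor a magnitude. With both measured values at the limit, the change from compound 2 to compound 3 is expected to be modest, the step that the limit leaves unreadable from compound 2 to compound 3 being an estimate rather than a reading. Compound 3 is accordingly estimated at 30000 nM, within a range from 8000 nM to 120000 nM, and this assay is likely to return only a limit for it again.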

Compound 3, half-maximal inhibitory concentration: > 25000 nM
Compound 3 ended at the assay's limit; the forecaster's own chance of this, stated with the estimate: 75%; the middle value lies beyond the limit too.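

Among the compounds shown here, no step among compound 1, compound 2 and compound 3 can be read, since each gives only a limit in this assay and not a number: the limit of > 25000 nM in this assay, at which 3 of the 3 values shown sit. On these data alone, what stays open is whether these three compounds differ at all, and whether any other group on that same nitrogen would give a readable number.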